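Removing One Fluorine from a Weak Cell-Growth Inhibitor

This account rests on a few compounds, and the source may have more. Where it says the series, first, only, none or still open, it means among the compounds named here.

Three measured compounds share a core and differ only in the aromatic group at one end. Compound 1 `Cc1ccc(-c2cc(COC3(C(F)(F)F)Oc4ccccc4C=C3C(=O)O)on2)cc1` carries a 4-methylphenyl group, compound 2 `O=C(O)C1=Cc2ccccc2OC1(OCc1cc(-c2ccc([N+](=O)[O-])cc2)no1)C(F)(F)F` a 4-nitrophenyl group and compound 3 `O=C(O)C1=Cc2ccccc2OC1(OCc1cc(-c2ccc(F)cc2F)no1)C(F)(F)F` a 2,4-difluorophenyl group. In a functional assay on HeLa cells (Homo sapiens) for inhibition, read by MTT assay, with a stated time of 24 h (on this read-out lower numbers stand for stronger inhibition and higher numbers for weaker inhibition), compound 1 gives 33400 nM. For compound 2 the assay reports only a limit, > 150000 nM. For compound 3 the assay likewise reports only a limit, > 150000 nM. Compound 3 thus stands at the limit of > 150000 nM in this assay, at which 2 of the 3 values shown sit, so an at least 4.4-fold higher number from compound 1 to compound 3 (0.65 log units; beyond the scatter) and an at least 4.4-fold higher number from compound 1 to compound 2 (0.65 log units; beyond the scatter) are both read against that limit, while a step that the two limits leave unreadable from compound 2 to compound 3 cannot be read at all.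

Compound 4 `O=C(O)C1=Cc2ccccc2OC1(OCc1cc(-c2ccc(F)cc2)no1)C(F)(F)F` differs from compound 3 by hydrogen in place of fluoro on an aromatic carbon. Within the data shown here, none of the measured steps removes a single fluoro from this aromatic ring, so no step bears directly on the change. The nearest comparison is compound 1, whose 4-methylphenyl group gives 33400 nM. Compound 4 is therefore expected to fall between that value and the limit, most likely still close to the limit, with a step of an at least 1.6-fold lower number from compound 3 to compound 4 (0.22 log units; that floor lies within the scatter). The estimate for compound 4 is 90000 nM, with a range from 30000 nM to 300000 nM.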

Compound 4, half-maximal inhibitory concentration: > 150000 nM
Compound 4: only a limit was reported (the forecaster's own chance of this, stated with the estimate: 55%); middle value at least 1.6-fold (0.22 log units) away from the limit.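

In this assay compound 4 gives only a limit, > 150000 nM, so going from the 2,4-difluorophenyl group to the 4-fluorophenyl group yields no measured number at this end of the molecule. Among these compounds, with fluoro in place of methyl on the aromatic carbon, the result shows an at least 4.4-fold higher number from compound 1 to compound 4 (0.65 log units; beyond the scatter), so a single fluoro on this ring does not match the 4-methylphenyl group of compound 1, which is the only one of the four compounds with a number. The steps from compound 2 and from compound 3 to compound 4 cannot be read, so the removal of this one fluoro has no readable size, and the series now stands largely at one value: the limit of > 150000 nM in this assay, at which 3 of the 4 values shown sit.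

The compounds shown leave open whether any group other than 4-methylphenyl at this end gives a number rather than a limit, and an unsubstituted phenyl, a 4-methoxyphenyl or a 4-ethylphenyl group would bear on that. They also leave open how compound 2, compound 3 and compound 4 stand relative to each other, since no order among them can be taken from limits.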